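Iodo for ethynyl on a nucleoside core: expected outcome

The compounds below may be only part of what the source reports. "The series", "measured", "known", "first", "only" and "open" are said of these compounds alone.

Measured so far:
- compound 1, `C#Cc1cn([C@@H]2O[C@H](CO)[C@@H](O)[C@H]2O)c2ncnc(NC)c12`: > 20000 nM
- compound 2, `C#Cc1cn([C@@H]2O[C@H](CO)[C@@H](O)[C@H]2O)c2nc(C)nc(N)c12`: > 20000 nM
- compound 3, `Cc1nc(N)c2c(I)cn([C@@H]3O[C@H](CO)[C@@H](O)[C@H]3O)c2n1`: > 20000 nM

All three measured compounds were tested in a functional assay on HCT-116 cells (Homo sapiens), read by MTT assay, with a stated time of 72 h; a higher number here means a weaker inhibitor, a lower number a stronger inhibitor. For compound 1 the value is a limit of the assay, not a number. For compound 2 the value is likewise a limit. For compound 3 the value is again a limit. The evidence therefore consists of the limit of > 20000 nM in this assay, at which 3 of the 3 values shown sit, and nothing more.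

Compound 2 and compound 3 differ by iodo in place of ethynyl on an aromatic carbon. The step from one to the other, a step that the two limits leave unreadable from compound 2 to compound 3, cannot be read because both values are limits. Compound 1 and compound 2 share the same atoms joined differently; the difference between the two cores is not broken down here.

Compound 4, `CNc1ncnc2c1c(I)cn2[C@@H]1O[C@H](CO)[C@@H](O)[C@H]1O`, is not yet measured. It differs from compound 1 by iodo in place of ethynyl on an aromatic carbon, the same change as from compound 2 to compound 3, at a place described in the same words. Since the earlier step stays hidden behind the limit, the step that the limit leaves unreadable from compound 1 to compound 4 is an estimate resting only on compound 1 sitting at > 20000 nM and on the same change leaving compound 3 at its limit. Compound 4 is expected to give about 30000 nM in this assay, estimated between 12000 nM and 100000 nM, most likely again reported as a limit.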

Compound 4, half-maximal inhibitory concentration: > 100000 nM
Compound 4 was reported as a limit; the forecaster's own chance of this, stated with the estimate: 85%; middle value at least 3.3-fold (0.52 log units) away from the limit.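

In this assay compound 4 gives > 100000 nM, which is a limit of the assay and not a number. Compound 1 is also reported only as a limit, and the step between compound 1 and compound 4 cannot be read. The compounds shown leave open how strongly any of the four acts on these cells, and whether iodo or ethynyl gives the stronger inhibitor on either core.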